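Piperazine Aryl Exchange in a Paw Edema Series

A few compounds are considered here, and "the series" means these few. Any claim that something is new, unique, unknown or untested is made for them only; others in the source may bear on it.

Measured compounds:
compound 1 `CCOC(=O)C1CCN(Cn2nc(C(C)c3ccc(CC(C)C)cc3)oc2=S)CC1`: 73.9%
compound 2 `CC(C)Cc1ccc(C(C)c2nn(CN3CCN(c4cccc(Cl)c4)CC3)c(=S)o2)cc1`: 64.3%

In a functional assay on the whole organism (strain Wister albino) for inhibition, with Rattus norvegicus as the target, read by paw edema, with stated times of 30 min and 3 h, at a dose of 10 mg/kg by the oral route (a lower number here means less inhibition, a higher number more inhibition at the dose given (going by the name of the read-out)), compound 1 gives 73.9%. In this assay compound 2 gives 64.3%. Among the measured compounds shown here, these are the only two numbers known, and they lie within the scatter of each other, so neither compound can be set apart from the other on this evidence.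

Compound 3 `CCOc1ccccc1N1CCN(Cn2nc(C(C)c3ccc(CC(C)C)cc3)oc2=S)CC1` has not yet been measured. It differs from compound 2 in one place: 2-ethoxyphenyl in place of 3-chlorophenyl on an amine nitrogen in a ring. For the measured compounds named here, no pair of measured compounds shows what such an exchange does in this assay; the two known numbers only show that the shared core with two quite different substituents on that ring nitrogen gave results within the scatter. The step from compound 2 to compound 3 is therefore expected to be small, a number 0.7 percentage points higher from compound 2 to compound 3 (within the scatter), with no direction that can be argued from the data. Compound 3 is estimated at 65%, between 50% and 78%.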

Compound 3, a percentage reported as inhibition, in the whole organism at one dose (the size of the read-out at that dose, not a potency): 44.6%
Estimate against measurement, compound 3: 20.4 percentage points above; measured number outside the range, below it.
By their numbers in this assay, from the lowest: compound 3; then compounds 2 and 1 (each within the scatter of the next).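

The aryl group on this amine nitrogen in a ring is not a silent position: in this assay, 2-ethoxyphenyl in place of 3-chlorophenyl gives a number 19.7 percentage points lower from compound 2 to compound 3 (beyond the scatter), with the rest of the molecule unchanged. The two earlier numbers, within the scatter of each other and from compounds differing in more than the aryl group, could not show that a single exchange here moves the paw edema result this far. Nothing measured in this account speaks to the reason for this step.

The exchange changes both the group on the phenyl ring and its place on that ring, so the compounds shown do not tell which of the two goes with the lower number. A 2-chlorophenyl, a 3-ethoxyphenyl or an unsubstituted phenyl on the same nitrogen remains an open case.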